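A few compounds are considered here, and "the series" means these few. Any claim that something is new, unique, unknown or untested is made for them only; others in the source may bear on it.

Compound 1 `Cc1cccc(Nc2nc(-c3ccncc3-c3ccc(S(C)(=O)=O)cc3)cs2)c1`, compound 2 `Cc1cccc(Nc2nc(-c3ccncc3)c[nH]2)c1` and compound 3 `Cc1cccc(Nc2nc(-c3ccncc3CCCO)cs2)c1` share a core and were tested in a functional assay on RCC4 cells (Homo sapiens) for inhibition, read by XTT assay, with a stated time of 4 days; a lower number here means a stronger inhibitor, a higher number a weaker inhibitor. In this assay compound 1 gives 1600 nM; 1620 nM (2 entries), as shown by the several entries of compound 1 in this assay, 1600 nM; 1620 nM (2 entries). In this assay compound 2 gives > 40000 nM; 40700 nM (2 entries), as shown by the several entries of compound 2 in this assay, > 40000 nM; 40700 nM (2 entries). Compound 3 gives 6920 nM in this assay, a higher and therefore weaker number than that of compound 1, and on the numbers shown it stands between the other two compounds.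

Compound 4 `C#Cc1cnccc1-c1csc(Nc2cccc(C)c2)n1` has not been measured yet. It differs from compound 3 by ethynyl in place of 3-hydroxypropyl on an aromatic carbon. Among the compounds with values here, no measured pair isolates this particular change, so no step can be quoted for it. Compound 4 is expected to stay close to compound 3, with a 1.4-fold lower number from compound 3 to compound 4 (0.14 log units; within the scatter) as the expected step, in no clear direction beyond the usual scatter. In this assay compound 4 is estimated at 5000 nM, within a range from 1500 nM to 20000 nM.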

Compound 4, half-maximal inhibitory concentration: 1380 nM
The estimate for compound 4 lay 3.6-fold (0.56 log units) above the measured number; measured number below the stated range.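

In this assay, placing ethynyl in place of 3-hydroxypropyl on this aromatic carbon, two atoms from the ring nitrogen, gives a 5.0-fold lower number from compound 3 to compound 4 (0.70 log units; beyond the scatter), so the number responds to the group held here. The entering group has fewer heavy atoms and no hydrogen-bond donor, so the donor of 3-hydroxypropyl is not needed to reach this range: compound 1, which also has none in its group here, gives 1600 nM; 1620 nM (2 entries), and compound 4 gives 1380 nM. Nothing measured here explains why the number falls.

The change alters size, the donor and the triple bond all at once, and the compounds shown cannot separate these. From the compounds shown here alone, how a plain propyl chain, an amine or a nitrile would compare at this position remains open.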